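The compounds below may be only part of what the source reports. "The series", "measured", "known", "first", "only" and "open" are said of these compounds alone.

Of the compounds shown here, three have been measured in a functional assay (blood) for inhibition, with Homo sapiens as the target; a higher number here means a weaker inhibitor, a lower number a stronger inhibitor. Compound 1 `CO[C@]1(c2cc(F)cc(Sc3ccc(/C(C)=N/OCC#N)cc3)c2)CCO[C@@H](C)C1` gives 40 nM, compound 2 `COC(=O)C(C)(C)CO/N=C(\C)c1ccc(Sc2cc(F)cc(C3CCOCC3)c2)cc1` gives 420 nM, and compound 3 `COC1(c2cc(F)cc(Sc3ccc4c(c3)CC/C4=N\O)c2)CCOCC1` gives 290 nM. Compound 2 has the highest number of the three in this assay: its value sits within the scatter of that of compound 3, while compound 1 stands beyond the scatter with a far lower number.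

Compound 4 `C/C(=N\OC(C)C)c1ccc(Sc2cc(F)cc(C3CCOCC3)c2)cc1` has not yet been measured. It differs from compound 2 in one place: isopropyl in place of 2-(methoxycarbonyl)-2-methylpropyl on an oxygen. The oxygen attached to the double-bonded nitrogen thus carries a much smaller group in compound 4, and the methoxycarbonyl and its two acceptors are gone.

Going by the values given here, no measured pair shows this change, so the step can only be guessed. Starting from compound 2 at 420 nM, a modest step toward a lower number is expected, a 1.7-fold lower number from compound 2 to compound 4 (0.23 log units; within the scatter), though it may well stay within the scatter. Compound 4 is therefore estimated at 250 nM, with a plausible range from 80 nM to 800 nM.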

Compound 4, half-maximal inhibitory concentration: 920 nM
Compound 4: middle estimate off by 3.7-fold (0.57 log units), on the low side; measured number outside the range, above it.
By their numbers in this assay, from the lowest: compound 1; then compounds 3 and 2 (each within the scatter of the next); then compound 4.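

In this assay, putting isopropyl in place of 2-(methoxycarbonyl)-2-methylpropyl on the oxygen gives a 2.2-fold higher number from compound 2 to compound 4 (0.34 log units; beyond the scatter), a modest step but one that goes toward a weaker inhibitor. Going by these compounds alone, this is the first sign that the group on this oxygen affects the result, and here the much smaller group without the methoxycarbonyl does worse than the larger one. Since the change alters both the size of the group and the presence of the methoxycarbonyl, no information here separates the two or explains the step.

The compounds shown leave open whether the methoxycarbonyl itself matters or whether the length of the chain is enough. A plain longer carbon chain, a carboxylic acid or an amine on this oxygen would help to tell these apart.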